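The compounds below may be only part of what the source reports. "The series", "measured", "known", "first", "only" and "open" are said of these compounds alone.

Values in an ADME assay on HepG2 cells (Homo sapiens) for cytotoxicity, with a stated time of 72 h; a lower number here means that less compound is needed, a higher number that more compound is needed for the effect:
compound 1 `CSc1ccc(NC(=O)Nc2cc(C)nc3ccccc23)cc1`: 16000 nM
compound 2 `Cc1cc(NC(=O)Nc2ccccc2N)c2ccccc2n1`: > 25000 nM (a limit)
compound 3 `Cc1cc(NC(=O)Nc2ncccc2C)c2ccccc2n1`: > 25000 nM (a limit)
compound 4 `Cc1cc(NC(=O)Nc2ccc(Cl)cc2)c2ccccc2n1`: not yet measured

Compound 3 stands at > 25000 nM, which is a limit and not a number. This is the limit of > 25000 nM in this assay, at which 2 of the 3 values shown sit. Compound 4 carries 4-chlorophenyl in place of 3-methylpyridin-2-yl on an amide-type nitrogen. Among the measured compounds shown here, the only measured step bearing on this is a step that the two limits leave unreadable from compound 2 to compound 3, so it gives no size to carry over. For the measured compounds named here, the expectation therefore leans on compound 1 at 16000 nM, the single number in this assay. The expected result is an at least 1.4-fold lower number from compound 3 to compound 4 (0.16 log units; that floor lies within the scatter), towards less compound needed, though it may not be readable. For compound 4 the estimated value is 17000 nM, with an expected range of 7000 nM to 35000 nM.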

Compound 4, half-maximal effective concentration: > 25000 nM
Compound 4: only a limit was reported (the forecaster's own chance of this, stated with the estimate: 45%); at least 1.4-fold (0.16 log units) between middle value and limit.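

Compound 4 joins compound 2 and compound 3 at the same limit, which is not a number: the limit of > 25000 nM in this assay, at which 3 of the 4 values shown sit. The steps among these three compounds cannot be read. In this assay, among the compounds shown here, the one readable step, with chloro in place of methylsulfanyl on an aromatic carbon, is an at least 1.5-fold higher number from compound 1 to compound 4 (0.19 log units; that floor lies within the scatter), so the printed floor alone does not place the change beyond the scatter.

From the compounds shown here alone, the true size of that step remains open, as does any order among compound 2, compound 3 and compound 4. Also open, going by these compounds, is whether an amine or a carboxylic acid in place of chloro on that aromatic carbon would give a number rather than a limit.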